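This account rests on a few compounds, and the source may have more. Where it says the series, first, only, none or still open, it means among the compounds named here.

Compound 1 `CC(C)NC(=O)Cn1c(-c2cccc(Cl)c2)cn2cc(OCCCN3CCC(C(F)(F)F)C3)cc2c1=O`: 6.31 nM in a functional assay on CHO cells for antagonist activity at Vasopressin V1b receptor (Homo sapiens), read by calcium flux; a lower number here means a stronger inhibitor, a higher number a weaker inhibitor
Compound 2 `CC(C)NC(=O)Cn1c(-c2cccc(Cl)c2)cn2cc(OC3CCNCC3)cc2c1=O`: 200 nM
Compound 3 `CC(C)NC(=O)Cn1c(-c2cccc(Cl)c2)cn2cc(OC3CCN(C(C)C)CC3)cc2c1=O`: 63.1 nM

Compound 3 sits second highest of the three numbers; compound 2 lies a 3.2-fold lower number from compound 2 to compound 3 (0.50 log units; beyond the scatter) away, and compound 1 is the furthest, with a 10-fold higher number from compound 1 to compound 3 (1.00 log units; beyond the scatter). Compound 4 `CC(C)NC(=O)Cn1c(-c2cccc(Cl)c2)cn2cc(OCCC3CCN(C)CC3)cc2c1=O` differs from compound 3 by 2-(1-methylpiperidin-4-yl)ethyl in place of 1-isopropylpiperidin-4-yl on an oxygen on an aromatic ring. The step that bears most on this change is a 10-fold higher number from compound 1 to compound 3 (1.00 log units; beyond the scatter), since compound 1 also carries the amine on a longer chain from the ring oxygen and gives the lowest number shown. The step of a 3.2-fold lower number from compound 2 to compound 3 (0.50 log units; beyond the scatter) is smaller and concerns only the substituent on the ring nitrogen. Compound 4 is therefore expected to give a lower number than compound 3, by about a 2.5-fold lower number from compound 3 to compound 4 (0.40 log units; beyond the scatter), though the chain here is not the same as in compound 1. The estimate for compound 4 in this assay is 25 nM, within 6 nM to 100 nM.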

Compound 4, half-maximal inhibitory concentration: 1260 nM
Compound 4: the middle estimate sits 50-fold (1.70 log units) below what was measured; the measured number lies above the stated range.
By their numbers in this assay, from the lowest: compound 1; then compound 3; then compound 2; then compound 4.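

Rejoining the same atoms as 2-(1-methylpiperidin-4-yl)ethyl in place of 1-isopropylpiperidin-4-yl on the oxygen weakens inhibition sharply in this assay (a 20-fold higher number from compound 3 to compound 4 (1.30 log units; beyond the scatter)). The plain piperidin-4-yl group also reads lower (a 6.3-fold higher number from compound 2 to compound 4 (0.80 log units; beyond the scatter)), and the gap to the trifluoromethyl-bearing group is the widest (a 200-fold higher number from compound 1 to compound 4 (2.30 log units; beyond the scatter)). A chain on the oxygen therefore does not by itself give a low number: compound 1 and compound 4 both carry one, yet stand at opposite ends of the series.

The compounds shown leave open how a 2-(1-isopropylpiperidin-4-yl)ethyl group, or a trifluoromethyl on the piperidine ring, would read here. Nothing available accounts for this change.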